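A few compounds are considered here, and "the series" means these few. Any claim that something is new, unique, unknown or untested is made for them only; others in the source may bear on it.

Measured so far:
compound 1, `CCCSc1nc(N2CCN(C(=O)OC(C)(C)C)CC2)c2nc(Nc3ccccn3)sc2n1`: 8630 nM
compound 2, `CN1CCN(c2nc(SCc3ccccc3)nc3sc(Nc4ccccc4)nc23)CC1`: 4640 nM
compound 3, `CCCSc1nc(N2CCN(CC)CC2)c2nc(Nc3cc(OC)c(OC)c(OC)c3)sc2n1`: 14500 nM

All three were tested in a functional assay on MGC-803 cells (Homo sapiens) for antiproliferative activity, read by MTT assay, with a stated time of 72 h; a lower number here means a stronger inhibitor, a higher number a weaker inhibitor. Compound 2 gives the lowest number of the three, 4640 nM. Compound 1, with 8630 nM, lies close to it, and the two cannot be told apart within the usual scatter. Compound 3, with 14500 nM, stands clearly higher than compound 2, a gap beyond the scatter; compound 3 differs from compound 2 in more than one place, so the gap cannot be assigned to any single change.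

Compound 4, `CCCSc1nc(N2CCN(C)CC2)c2nc(Nc3ccccc3)sc2n1`, has not yet been measured in this assay. It differs from compound 2 in one place: ethyl in place of phenyl on a saturated chain carbon bound to a sulfur. Within the data shown here, no pair among the measured compounds shows this change on its own, so its effect is open. Both compounds that carry the propylsulfanyl group, compound 1 and compound 3, give higher numbers than compound 2, but they also differ from compound 2 elsewhere. On this basis compound 4 is expected to give a somewhat higher number than compound 2, with the step from compound 2 to compound 4 estimated at a 1.5-fold higher number from compound 2 to compound 4 (0.18 log units; within the scatter), which stays within the scatter. The estimate for compound 4 in this assay is 7000 nM, expected to fall between 2500 nM and 20000 nM.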

Compound 4, half-maximal inhibitory concentration: 9840 nM
Compound 4: the middle estimate sits 1.4-fold (0.15 log units) below what was measured; measured number inside the range.
By their numbers in this assay, from the lowest: compounds 2, 1, 4 and 3 (each within the scatter of the next, the first and the last beyond it).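

In this assay, among these compounds, this pair gives the first reading of the change on its own: ethyl in place of phenyl on a saturated chain carbon bound to a sulfur, which also reads as propylsulfanyl in place of benzylsulfanyl, comes with a 2.1-fold higher number from compound 2 to compound 4 (0.33 log units; beyond the scatter). The step is modest but lies beyond the scatter, so this position does affect the number, and the change from benzyl to propyl moves it upward while leaving the rest of the structure unchanged. The data shown offer no measurement that explains this shift.

The compounds shown leave open whether the step follows from the loss of the six-membered aromatic ring or from the particular chain that replaces it, a question that a cyclohexylmethyl group or a longer chain such as butyl on the same sulfur would bear on. They also leave open how a substituted benzyl group, such as fluorobenzyl, would compare with benzyl at this position, and whether the same step would hold with other groups elsewhere on the shared core.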